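The compounds below may be only part of what the source reports. "The series", "measured", "known", "first", "only" and "open" are said of these compounds alone.

Series notes. Compound 3 `COc1ccc(-c2c(S(=O)(=O)c3ccc(F)cc3)cnc3cc(F)ccc23)cc1` stands highest of the three numbers in an ADME assay on microsomes from liver (Homo sapiens) for metabolic stability, tested at 2.5 uM (on this read-out higher numbers stand for fast clearance and lower numbers for slow clearance), at 1.77 mL/min. Compound 1 `O=S(=O)(c1cc(F)cc(F)c1)c1cnc2cc(F)ccc2c1-c1ccc(Cl)cc1` gives 0.03 mL/min in this assay, and compound 2 `N#Cc1ccc2c(-c3ccc(Cl)cc3)c(S(=O)(=O)c3ccc(F)cc3)cnc2c1` gives 0.01 mL/min; both gaps from compound 3 lie beyond the scatter. Compound 4 `O=S(=O)(c1ccc(F)cc1)c1cnc2cc(F)ccc2c1-c1ccc(Cl)cc1` has not yet been measured. It differs from compound 3 by chloro in place of methoxy on an aromatic carbon. Among the compounds with values here, no step between measured compounds covers this change, so the forecast rests on the chloro-bearing compound 1 at 0.03 mL/min and compound 2 at 0.01 mL/min, both far under compound 3. A large downward step is expected, a 35-fold lower number from compound 3 to compound 4 (1.55 log units; beyond the scatter), in this assay. Compound 4 is therefore estimated at 0.05 mL/min, with a range from 0.01 mL/min to 0.3 mL/min in this assay.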

Compound 4, intrinsic clearance in a liver preparation (reported as CLH), per the amount of preparation that the assay uses: 1.23 mL/min
Beside the measured number, compound 4's estimate is 25-fold (1.39 log units) below it; measured number above the stated range.
By their numbers in this assay, from the lowest: compound 2; then compound 1; then compounds 4 and 3 (each within the scatter of the next).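

In this assay, 4-chlorophenyl in place of 4-methoxyphenyl gives a 1.4-fold lower number from compound 3 to compound 4 (0.16 log units; within the scatter), so this change does not separate the two compounds. Among the compounds carrying 4-chlorophenyl, the large steps lie elsewhere: fluoro in place of cyano gives a 120-fold higher number from compound 2 to compound 4 (2.09 log units; beyond the scatter), and 4-fluorophenyl in place of 3,5-difluorophenyl gives a 41-fold higher number from compound 1 to compound 4 (1.61 log units; beyond the scatter). Nothing at hand bears on the cause of these steps. Still open, as far as these compounds go, is whether an amine or a carboxylic acid in place of chloro would read like chloro and methoxy. Also open, from the compounds shown here alone, is whether the cyano and 3,5-difluorophenyl changes would give similar steps with 4-methoxyphenyl present.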